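Piperazine to piperidine in the dimethylcarbamoyl series

The source may hold more compounds than are shown below. What is called first, only, known or untested is meant among the compounds shown, and "the series" means these compounds.

Measured in a physicochemical assay for lipophilicity, using the shake flask method, at pH 7.4; on this read-out lower numbers stand for lower lipophilicity and higher numbers for higher lipophilicity:
- compound 1 `CN(C)[C@H]1CC[C@H](Nc2ncnc3[nH]cc(C4CCCC4)c23)CC1`: 1.7
- compound 2 `CC(=O)N1CCN([C@H]2CC[C@H](Nc3ncnc4[nH]cc(C5CCOCC5)c34)CC2)CC1`: 1.3
- compound 3 `CN(C)C(=O)N1CCN([C@H]2CC[C@H](Nc3ncnc4[nH]cc(C5CCOCC5)c34)CC2)CC1`: 1.5

On these numbers, compound 3 at 1.5 lies within the scatter of both compound 1 and compound 2.

The next compound to consider is compound 4 `CN(C)C(=O)C1CCN([C@H]2CC[C@H](Nc3ncnc4[nH]cc(C5CCOCC5)c34)CC2)CC1`. The structural change is 4-(dimethylcarbamoyl)piperidin-1-yl in place of 4-(dimethylcarbamoyl)piperazin-1-yl on a saturated ring carbon.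

Among the measured compounds shown here, only one measured step bears on this group, a number 0.20 log units higher from compound 2 to compound 3 (within the scatter). It alters the group at its carbonyl carbon and leaves the ring untouched, so it offers only indirect guidance. For the measured compounds named here, no measured pair shows the ring change itself. On this limited evidence, no step beyond the scatter is expected in this assay, although the range is kept wide. The expected change is a number 0.20 log units lower from compound 3 to compound 4 (within the scatter). The estimate for compound 4 is 1.3, with an expected range from 0.8 to 1.8.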

Compound 4, distribution coefficient: -0.1
For compound 4 the middle estimate is 1.40 log units above the measured one; measured number outside the range, below it.
By their numbers in this assay, from the lowest: compound 4; then compounds 2, 3 and 1 (each within the scatter of the next, the first and the last beyond it).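

In this assay the move to 4-(dimethylcarbamoyl)piperidin-1-yl brings a number 1.60 log units lower from compound 3 to compound 4 (beyond the scatter) and, set against 4-acetylpiperazin-1-yl, a number 1.40 log units lower from compound 2 to compound 4 (beyond the scatter) although the groups leaving and entering match in their counted heavy atoms, hydrogen-bond donors and hydrogen-bond acceptors. The earlier step altered only the carbonyl substituent and stayed within the scatter, whereas this change exchanges a ring nitrogen for a ring carbon and shows that this group can shift the read-out well beyond the scatter. No measurement at hand accounts for the size of this step.

Still open, from the compounds shown here alone, is whether a piperidine carrying acetyl in place of dimethylcarbamoyl would stay close to compound 4. A carboxylic acid or a primary amine on the same piperidine ring would test how far the result depends on the amide.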